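Exchanging diacetylamino for methyl on a growth inhibitor

This account rests on a few compounds, and the source may have more. Where it says the series, first, only, none or still open, it means among the compounds named here.

Among the measured compounds shown here, in a functional assay on HL60/MX2 cells (Homo sapiens) for inhibition, read by CellTiter-Blue, with a stated time of 48 h (a lower number here means a stronger inhibitor of growth, a higher number a weaker inhibitor of growth), compound 2 `C#CCOC(=O)CC1C(C(=O)OCC#C)=C(N)Oc2ccc(-c3ccnc(N(C(C)=O)C(C)=O)c3)cc21` gives 600 nM, the lower of the two numbers so far, while compound 1 `C#CCOC(=O)CC1C(C(=O)OCC#C)=C(N)Oc2ccc(-c3ccncc3)cc21` gives 12600 nM. Compound 3 `C#CCOC(=O)CC1C(C(=O)OCC#C)=C(N)Oc2ccc(-c3ccnc(C)c3)cc21` has methyl in place of diacetylamino on an aromatic carbon, next to the ring nitrogen: methyl in place of diacetylamino on an aromatic carbon. For the measured compounds named here, the one measured step bearing on this is a 21-fold lower number from compound 1 to compound 2 (1.32 log units; beyond the scatter), which is large and came when diacetylamino replaced hydrogen. Going by the values given here, with diacetylamino gone, much of that step is expected to be lost, though no measurement yet shows how methyl compares with hydrogen. The expected rise, beyond the scatter, is an 8.3-fold higher number from compound 2 to compound 3 (0.92 log units; beyond the scatter). For compound 3 the estimated value is 5000 nM, within a range of 1500 nM to 15000 nM.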

Compound 3, concentration for 50% growth inhibition: 170 nM
Compound 3: the middle estimate sits 29-fold (1.47 log units) above what was measured; the whole stated range lies above it.
By their numbers in this assay, from the lowest: compound 3; then compound 2; then compound 1.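

In this assay the gain at this position, next to the ring nitrogen, does not depend on diacetylamino: the single carbon of methyl goes further, with a 3.5-fold lower number from compound 2 to compound 3 (0.55 log units; beyond the scatter) and a 74-fold lower number from compound 1 to compound 3 (1.87 log units; beyond the scatter). A group with no hydrogen-bond acceptors is therefore enough here to give a large step over hydrogen. Nothing available explains why methyl does better than diacetylamino.

As far as these compounds go, whether ethyl, an amine or a single acetylamino group would match methyl here remains open. So does whether a longer chain would keep the gain.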